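The compounds below may be only part of what the source reports. "The series", "measured", "known", "first", "only" and "open" are said of these compounds alone.

Going by the values given here, compound 2 `CSc1ccccc1N1CCN(Cc2nc3ccccc3[nH]2)CC1` gives 42% in an assay on HEK293 cells with D(4) dopamine receptor (Homo sapiens) as the target, read by FLIPR; a lower number here means a smaller maximal response, a higher number a larger maximal response; of the two numbers measured so far it stands lowest, with compound 1 `N#Cc1ccccc1N1CCN(Cc2nc3ccccc3[nH]2)CC1` nearest at 46%, a gap that lies within the scatter. Compound 3 `Cc1cccc(N2CCN(Cc3nc4ccccc4[nH]3)CC2)n1` has not yet been measured in this assay. Its difference from compound 2: 6-methylpyridin-2-yl in place of 2-(methylsulfanyl)phenyl on an amine nitrogen in a ring. Among the compounds with values here, the only measured step, a number 4 percentage points lower from compound 1 to compound 2 (within the scatter), exchanged one group on the same six-membered aromatic ring of carbon only; the step to compound 3 instead replaces that ring by one with 1 hetero atom bearing a methyl group, a change on which nothing measured speaks directly. Within the data shown here, as the one step in hand stayed within the scatter, no step beyond the scatter is expected in this assay for compound 3, though a wide range is kept open. For compound 3 the estimated value in this assay is 42%, between 22% and 65%. The expected step is no change at the digits printed from compound 2 to compound 3 (within the scatter).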

Compound 3, largest response reached (reported as efficacy), in percent of the reference or control that the assay uses: 36%
Compound 3: the middle estimate sits 6 percentage points above what was measured, within the range that was stated.
By their numbers in this assay, from the lowest: compounds 3, 2 and 1 (each within the scatter of the next).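

In this assay, 6-methylpyridin-2-yl on the amine nitrogen in the ring gives a number 6 percentage points lower from compound 2 to compound 3 (within the scatter), and the same group set against 2-cyanophenyl gives a number 10 percentage points lower from compound 1 to compound 3 (within the scatter). The earlier step only exchanged one substituent on a six-membered aromatic ring of carbon only, whereas these steps show that a ring with 1 hetero atom can take that place with no step beyond the scatter, so the three compounds cannot be ordered in this read-out. No supporting data bear on why the maximal response stays in this range.

On these data alone, compound 3 brings in the ring nitrogen and the methyl together, so their separate contributions remain open; an unsubstituted pyridin-2-yl would separate them. Also open, as far as these compounds go, is whether a non-aromatic group, such as cyclohexyl, would stay within the same range at this position.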